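The source may hold more compounds than are shown below. What is called first, only, known or untested is meant among the compounds shown, and "the series" means these compounds.

Measured so far in a functional assay on SNB-19 cells (Homo sapiens) for inhibition, read by sulforhodamine B assay, with a stated time of 48 h; a lower number here means a stronger inhibitor of growth, a higher number a weaker inhibitor of growth:
Compound 1 `COc1cc(-c2nn(-c3cccc(NC(=O)Nc4cccc(C(F)(F)F)c4)c3)cc2-c2ccncc2)ccc1Cl` gives 981 nM.
Compound 2 `COc1cc(-c2nn(-c3cccc(NC(=O)Nc4ccc(Cl)c(C(F)(F)F)c4)c3)cc2-c2ccncc2)ccc1Cl` gives 1240 nM.

Compound 2 stands at the higher of the two numbers in this assay, but the gap to compound 1 is within the scatter: a 1.3-fold higher number from compound 1 to compound 2 (0.10 log units; within the scatter). The next step leads to compound 3 `COc1cc(-c2nn(-c3cccc(NC(=O)c4ccccc4)c3)cc2-c2ccncc2)ccc1Cl` and alters the carbonyl side of the shared core: phenyl in place of (4-chloro-3-(trifluoromethyl)phenyl)amino on a carbonyl carbon. Going by the values given here, the only measured step, from compound 1 to compound 2, concerns a substituent on the very ring that now leaves and was within the scatter, so it offers no direct precedent for removing the amino nitrogen together with that ring. Without a comparable step, the expectation rests on the size of the change alone: a weaker inhibition of growth is expected for compound 3, with an estimate of 3000 nM (range 1000 nM to 10000 nM), which means an expected step of a 2.4-fold higher number from compound 2 to compound 3 (0.38 log units; beyond the scatter).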

Compound 3, concentration for 50% growth inhibition: 860 nM
The estimate for compound 3 lay 3.5-fold (0.54 log units) above the measured number; the measured number lies below the stated range.
By their numbers in this assay, from the lowest: compounds 3, 1 and 2 (each within the scatter of the next).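

In this assay, phenyl in place of (4-chloro-3-(trifluoromethyl)phenyl)amino on a carbonyl carbon gives a 1.4-fold lower number from compound 2 to compound 3 (0.16 log units; within the scatter), and phenyl in place of (3-(trifluoromethyl)phenyl)amino gives a 1.1-fold lower number from compound 1 to compound 3 (0.06 log units; within the scatter), so neither change moves the number beyond the scatter. Where the earlier step altered only a substituent on the ring, these steps show that this position also accepts losing the amino nitrogen with its hydrogen-bond donor, along with the trifluoromethyl group, without a change beyond the scatter. No evidence is available on why the number stays within the scatter.

Going by these compounds, it remains open whether the position accepts a group on the carbonyl carbon without an aromatic ring, such as a saturated amine or a longer alkyl chain. Also open, on these data alone, is whether a carboxylic acid on the entering phenyl would shift the number.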